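Chain Length at the Aryl Ether and Cytotoxicity

The compounds below may be only part of what the source reports. "The series", "measured", "known", "first", "only" and "open" are said of these compounds alone.

Compound 1 `CCCOc1c(Br)cc(/C=C2\CCC/C(=C\c3cccc([N+](=O)[O-])c3)C2=O)cc1OC` gives 1.51 ug/mL in a functional assay on SK-N-MC cells (Homo sapiens) for cytotoxicity, read by MTT assay; a higher number here means a weaker inhibitor, a lower number a stronger inhibitor.
Compound 2 `CCCCOc1c(Br)cc(/C=C2\CCC/C(=C\c3cccc([N+](=O)[O-])c3)C2=O)cc1OC` gives 25.4 ug/mL in this assay.
Compound 3 `CCOc1c(Br)cc(/C=C2\CCC/C(=C\c3ccc([N+](=O)[O-])cc3)C2=O)cc1OC` gives 3.91 ug/mL in this assay.

Compounds 1 and 2 share a core and differ in one place, (methyl in place of hydrogen on a saturated chain carbon, three bonds along the chain from an oxygen on an aromatic ring). That step, a 17-fold higher number from compound 1 to compound 2 (1.23 log units; beyond the scatter), is the only measured one in the set. Compound 3 carries a different core from compound 1, and the difference between the two cores is not broken down here; the values alone show that compound 3 sits between compound 1 and compound 2.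

Compound 4 `CCCOc1c(Br)cc(/C=C2\CCC/C(=C\c3ccc([N+](=O)[O-])cc3)C2=O)cc1OC` has not yet been measured. It differs from compound 3 by methyl in place of hydrogen on a saturated chain carbon, two bonds along the chain from an oxygen on an aromatic ring. For the measured compounds named here, this is the same kind of change as the one from compound 1 to compound 2, but not the same: there the added methyl sits three bonds along the chain from the oxygen on the aromatic ring, here two bonds along. Because a 17-fold higher number from compound 1 to compound 2 (1.23 log units; beyond the scatter) was large, lengthening the chain on the core of compound 3 is expected to move the number too, though the direction at a shorter chain is not fixed by any measured pair. Compound 4 is therefore expected to show a modest step, a 1.5-fold higher number from compound 3 to compound 4 (0.19 log units; within the scatter), with wide uncertainty. Compound 4 is estimated at 6 ug/mL, within 2 ug/mL to 20 ug/mL.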

Compound 4, half-maximal inhibitory concentration: 23.3 ug/mL
For compound 4 the middle estimate is 3.9-fold (0.59 log units) below the measured one, outside the stated range (above it).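

In this assay the ethoxy to propoxy change gives a 6.0-fold higher number from compound 3 to compound 4 (0.78 log units; beyond the scatter) and so moves the number the same way as the added methyl on the core of compound 1, but the two steps differ in size: the same change on two cores in this assay, a 17-fold higher number (1.23 log units; beyond the scatter) from compound 1 to compound 2 and a 6.0-fold higher number (0.78 log units; beyond the scatter) from compound 3 to compound 4, 2.8-fold (0.45 log units) apart, beyond the scatter of two such steps. The direction thus carried from one core to the other in these two pairs while the size did not, and one pair on each core cannot say whether the gap belongs to the core or to the place of the methyl, which sits two bonds along the chain from the oxygen in one pair and three bonds along in the other. With the propoxy chain held the same, 4-nitrophenyl in place of 3-nitrophenyl gives a 15-fold higher number from compound 1 to compound 4 (1.19 log units; beyond the scatter), so the difference between the cores is itself large at this chain and the size of a chain step cannot be assumed to transfer between them.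

The compounds shown leave open how an ethoxy chain behaves on the core of compound 1 and how a longer chain, such as butoxy, behaves on the core of compound 3, either of which would allow a comparison of the same step at the same place. They also leave open whether an amine or a carboxylic acid in place of the nitro group would keep the numbers seen here.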